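An Extra Methyl on a Potent Corticotropin Ligand

A few compounds are considered here, and "the series" means these few. Any claim that something is new, unique, unknown or untested is made for them only; others in the source may bear on it.

Going by the values given here, compound 1 `CCCC(C)n1c(CC)nc2c(-c3ccc(OC)cc3C)ccnc21` gives 0.8 nM in an assay for binding affinity to Corticotropin releasing factor receptor (Rattus norvegicus) (on this read-out higher numbers stand for weaker inhibition and lower numbers for stronger inhibition), one of only two numbers measured here. Compound 2 `CCCC(C)n1c(CC)nc2c(-c3ccc(OC)cc3C(F)(F)F)ccnc21` gives 0.74 nM, and the step of a 1.1-fold lower number from compound 1 to compound 2 (0.03 log units; within the scatter) places the two compounds together. Compound 3 `CCCC(C)n1c(CC)nc2c(-c3cc(C)c(OC)cc3C)ccnc21` differs from compound 1 by methyl in place of hydrogen on an aromatic carbon. No measured step follows this added methyl; the single step shown, a 1.1-fold lower number from compound 1 to compound 2 (0.03 log units; within the scatter), concerns a different change and stayed small. The expected step in this assay, a 1.3-fold higher number from compound 1 to compound 3 (0.10 log units; within the scatter), is therefore none beyond the scatter. Compound 3 is estimated at 1 nM, between 0.3 nM and 3 nM.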

Compound 3, inhibition constant: 0.6 nM
Compound 3: the middle estimate sits 1.7-fold (0.22 log units) above what was measured; the range from low to high includes it.
By their numbers in this assay, from the lowest: compounds 3, 2 and 1 (each within the scatter of the next).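

In this assay, methyl in place of hydrogen on this aromatic carbon, ortho to a methoxy group and para to a methyl group, gives a 1.3-fold lower number from compound 1 to compound 3 (0.12 log units; within the scatter). This ring position therefore accepts one added carbon without a change beyond the scatter, something the earlier step, made at a different place on the ring, could not show. Nothing available here bears on the reason for this result. The compounds shown leave open how an amine, a carboxylic acid or a longer chain at this carbon would fare in this assay.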